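Hydroxy for Chloro: Same Outcome Expected in Paw Edema

The source may hold more compounds than are shown below. What is called first, only, known or untested is meant among the compounds shown, and "the series" means these compounds.

Compound 2 `Cc1cccc(-c2nc3cc(Cl)ccc3[nH]2)n1` gives 39% in a functional assay on the whole organism with Rattus norvegicus as the target, read by paw edema, with a stated time of 3 h, at a dose of 100 mg/kg by the oral route; a lower number here means less inhibition, a higher number more inhibition at the dose given (going by the name of the read-out). Compound 1 `COc1ccc2[nH]c(-c3cccc(C)n3)nc2c1` gives 40% in this assay, and the two numbers lie within the scatter of each other, so neither stands apart. Within the data shown here, the only measured step, a number 1 percentage points lower from compound 1 to compound 2 (within the scatter), swaps one substituent at an aromatic carbon and stays within the scatter. Compound 3 `Cc1cccc(-c2nc3cc(O)ccc3[nH]2)n1` differs from compound 2 by hydroxy in place of chloro on an aromatic carbon. Among the measured compounds shown here, with that single step as the only guide, no shift beyond the scatter is expected, and the estimated step is a number 1 percentage points higher from compound 2 to compound 3 (within the scatter). Compound 3 is therefore estimated at 40%, with a range from 25% to 55%.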

Compound 3, a percentage reported as inhibition, in the whole organism at one dose (the size of the read-out at that dose, not a potency): 6%
The estimate for compound 3 lay 34 percentage points above the measured number, and the stated range ends above it.
By their numbers in this assay, from the lowest: compound 3; then compounds 2 and 1 (each within the scatter of the next).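

In this assay this position is not indifferent to its substituent, since the step of a number 33 percentage points lower from compound 2 to compound 3 (beyond the scatter) follows from hydroxy in place of chloro, although chloro and methoxy had stayed within the scatter of each other. The step of a number 34 percentage points lower from compound 1 to compound 3 (beyond the scatter) comes from hydrogen in place of methyl on the oxygen, so an oxygen at this position does not by itself keep the number up. Nothing at hand gives a reason for this drop. From the compounds shown here alone, whether an amine, a carboxylic acid or a longer chain such as ethoxy at this position would go with the number of compound 1 or of compound 3 remains open.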